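Cyclohexyl in place of benzyl on the hydroxamate series

The compounds below may be only part of what the source reports. "The series", "measured", "known", "first", "only" and "open" are said of these compounds alone.

Among the compounds with values here, compound 1 `Cc1ccc(C(=O)N(CC(=O)NCc2ccccc2)Cc2ccc(C(=O)NO)cc2)c(C)c1` is the reference point; in an assay on Sf9 cells for inhibition of protein deacetylase HDAC6 (Homo sapiens), read by fluorescence, with a stated time of 90 min (a lower number here means a stronger inhibitor, a higher number a weaker inhibitor), compound 1 gives 60 nM, the second highest of the three numbers measured so far. Within the data shown here, compound 2 `Cc1ccccc1C(=O)N(CC(=O)NCc1ccccc1)Cc1ccc(C(=O)NO)cc1` gives 30 nM in this assay, and the step of a 2.0-fold lower number from compound 1 to compound 2 (0.30 log units; within the scatter) is the only single-point change measured to date. Compound 3 `CN(C)c1ccc(C(=O)N(Cc2ccc(C(=O)NO)cc2)C(C)(C)C(=O)NCc2ccccc2)cc1` gives 70 nM in this assay; it differs from compound 1 in more than one place, so its value can only be set beside that of compound 1, and the two lie close together.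

Compound 4 `Cc1ccc(C(=O)N(CC(=O)NC2CCCCC2)Cc2ccc(C(=O)NO)cc2)c(C)c1` is the next member: cyclohexyl in place of benzyl on an amide-type nitrogen. Among the measured compounds shown here, no measured step touches this amide-type nitrogen; the one step available, a 2.0-fold lower number from compound 1 to compound 2 (0.30 log units; within the scatter), concerns the methyl on an aromatic carbon and lies within the scatter, so it carries no information about the group on the amide-type nitrogen. With nothing in the series pointing to a shift in either direction, the expectation for compound 4 in this assay is a number close to that of compound 1, the expected step being no change at the digits printed from compound 1 to compound 4 (within the scatter), not beyond the scatter. Compound 4 is therefore estimated at 60 nM, with a range from 25 nM to 150 nM.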

Compound 4, half-maximal inhibitory concentration: 40 nM
For compound 4 the middle estimate is 1.5-fold (0.18 log units) above the measured one, and the stated range covers the measured number.
By their numbers in this assay, from the lowest: compounds 2, 4, 1 and 3 (each within the scatter of the next, the first and the last beyond it).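

Working notes on the amide-type nitrogen: this is the first position in the series where the group on that nitrogen has been varied, and in this assay the step reads a 1.5-fold lower number from compound 1 to compound 4 (0.18 log units; within the scatter). On the core of compound 1, the aromatic ring of benzyl can therefore give way to the non-aromatic ring of cyclohexyl without a change that can be told apart from the scatter, so an aromatic ring at this place is not required to keep a number of this size. The swap alters the ring type and the heavy-atom count together, so this single pair cannot separate the two, and no data are at hand that explain the result.

Still open, as far as these compounds go, is whether a group of a different kind on this nitrogen, such as a piperidine carrying a basic amine, a carboxylic acid or a longer chain such as phenethyl, would move the number beyond the scatter. From the compounds shown here alone, it is also open whether cyclohexyl behaves in the same way on the cores of compound 2 and compound 3, where the group on the other amide differs.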